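A Mirror-Image Pair in a Whole-Animal Dose Study

The source may report more compounds than this note shows. Statements on the series, on what has been measured and on what is new or still open speak of the compounds shown alone.

Of the compounds shown here, three have been measured in a functional assay on the whole organism with Mus musculus as the target, with a stated time of 20 min; a higher number here means that more compound is needed for the effect, a lower number that less compound is needed. Compound 1 `CC(C)S(=O)(=O)Nc1ccc(N(C)C(=O)c2ccccc2)cc1` gives 0.1 mg/kg in this assay. Compound 3 `CC(C)S(=O)(=O)N(C)c1ccc(NC(=O)c2ccccc2)cc1` gives 0.01 mg/kg in this assay. Compound 2 `CC(=O)N[C@H]1CC[C@H](NS(=O)(=O)c2ccc(F)cc2)CC1` gives 10 mg/kg in this assay, the highest number of the three; its nearest neighbour is compound 1, whose number lies well beyond the usual scatter below it, and compound 3 stands further still. Compound 2 therefore needs more compound for the effect than either of the others.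

Compound 4 `CC(=O)N[C@H]1CC[C@@H](NS(=O)(=O)c2ccc(F)cc2)CC1` has not yet been measured. It differs from compound 2 in this way: the two compounds have the same atoms and bonds and differ only in configuration as drawn: 2 of 2 stereo elements differ (all stereocentres are inverted: mirror images); a stereocentre at a saturated ring carbon is drawn r in compound 2 and s in compound 4; a stereocentre at a saturated ring carbon is drawn r in compound 2 and s in compound 4. Within the data shown here, no step between two measured compounds of this study speaks to such a change, so the direction cannot be read from the data. With only an inversion of configuration, a change of either sign is possible, and nothing beyond the scatter is required. The step from compound 2 to compound 4 is expected to be no change at the digits printed from compound 2 to compound 4 (within the scatter). In this assay compound 4 is estimated at 10 mg/kg, within a range from 2 mg/kg to 50 mg/kg.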

Compound 4, minimum effective dose: 1 mg/kg
For compound 4 the middle estimate is 10-fold (1.00 log units) above the measured one, outside the stated range (below it).
By their numbers in this assay, from the lowest: compound 3; then compound 1; then compound 4; then compound 2.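

Among these compounds, the inversion of both stereocentres at the saturated ring carbons gives a 10-fold lower number from compound 2 to compound 4 (1.00 log units; beyond the scatter) in this assay, so configuration at these carbons can shift this whole-animal read-out on its own, which none of the earlier compounds could show. The step can be assigned to configuration alone because no atom or bond changes between the two structures: the fact that compounds 2 and 4 differ only in the configuration as drawn

Within this pair, the carbons drawn s go with the lower dose and those drawn r with the higher one. As far as these compounds go, this rests on a single pair, so it remains open whether the same inversion would shift the number in the same direction or by a similar size with other groups on the ring. A primary amine or a carboxylic acid in place of the acetamide, for example, could behave differently, and the compounds shown do not say why configuration matters here.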